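Urea series: benzyl in place of chlorophenyl

The source may report more compounds than this note shows. Statements on the series, on what has been measured and on what is new or still open speak of the compounds shown alone.

Measured compounds:
compound 1, `O=C(Nc1ccc(Cl)cc1)Nc1cccc(NC(=O)c2ccccn2)c1`, 3620 nM
compound 2, `O=C(Nc1cccc(NC(=O)c2ccccn2)c1)Nc1ccc2ccccc2c1`, 240 nM

Working notes. The assay is a functional assay on A549 cells (Homo sapiens) for antiproliferative activity, read by MTT assay, with a stated time of 48 h; a higher number here means a weaker inhibitor, a lower number a stronger inhibitor. In this assay compound 1 gives 3620 nM, the highest of the two numbers on hand, and its nearest neighbour is compound 2, whose value of 240 nM sits well beyond the scatter of compound 1. Within the data shown here, the two compounds share the same core and differ only in the aryl group on the outer urea nitrogen; no single-change step between them has been worked out, so only their two values can be compared.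

The next compound, compound 3, `O=C(NCc1ccccc1)Nc1cccc(NC(=O)c2ccccn2)c1`, is not yet measured. Relative to compound 1 its change is benzyl in place of 4-chlorophenyl on an amide-type nitrogen. Among the measured compounds shown here, no measured step of this kind exists, so the expectation rests on the two values above and the structural change alone. The step from compound 1 to compound 3 is expected to be a 1.9-fold higher number from compound 1 to compound 3 (0.29 log units; within the scatter), towards a weaker inhibitor, probably beyond the scatter. For compound 3 the value in this assay is estimated at 7000 nM, within a range from 1800 nM to 28000 nM.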

Compound 3, half-maximal inhibitory concentration: 2990 nM
Estimate against measurement, compound 3: 2.3-fold (0.37 log units) above; measured number inside the range.
By their numbers in this assay, from the lowest: compound 2; then compounds 3 and 1 (each within the scatter of the next).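

In this assay, benzyl in place of 4-chlorophenyl on an amide-type nitrogen gives a 1.2-fold lower number from compound 1 to compound 3 (0.08 log units; within the scatter), so this exchange produces no readable change, even though the chlorine is lost and the ring is carried on a benzyl group rather than attached directly. Compound 2 gives 240 nM with its own aryl group on the same urea nitrogen, so the position is not indifferent to every group, and the result shows that this particular change is not one that moves the number. Nothing at hand bears on the reason for this outcome.

Among these compounds, the single exchange changes two things at once. A 4-chlorobenzyl group on the same nitrogen would be needed to tell these two changes apart. Also open, going by these compounds, is how a longer chain such as phenethyl, or a benzyl group carrying an amine or a carboxylic acid, would behave at this position.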